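Ethoxycarbonyl in place of iodo on compound 1

The source may report more compounds than this note shows. Statements on the series, on what has been measured and on what is new or still open speak of the compounds shown alone.

Among the compounds with values here, in an ADME assay on MT4 cells (Homo sapiens) for cytotoxicity (on this read-out higher numbers stand for lower toxicity in this test and lower numbers for higher toxicity in this test), compound 1 `FC(F)(F)c1cccc(NC(=S)Nc2ccc(I)cc2)c1` gives 10000 nM, the lowest number measured so far. Compound 3 `C=C(C)CNC(=S)Nc1cccc(C(F)(F)F)c1` gives 43000 nM, the nearest value. Compound 2 `CC(=O)NC(=S)Nc1cccc(C(F)(F)F)c1` gives > 100000 nM, and this is a limit of the assay.

Compound 4 `CCOC(=O)c1ccc(NC(=S)Nc2cccc(C(F)(F)F)c2)cc1` has not yet been measured. It keeps the core of compound 1 but carries ethoxycarbonyl in place of iodo on an aromatic carbon, para to a large group (ethoxycarbonyl in place of iodo on an aromatic carbon). Within the data shown here, no measured step makes this change alone. The nearest steps replace the whole 4-iodophenyl: 2-methylprop-2-en-1-yl gives a 4.3-fold higher number from compound 1 to compound 3 (0.63 log units; beyond the scatter), and acetyl gives an at least 10-fold higher number from compound 1 to compound 2 (1.00 log units; beyond the scatter). Both lead to higher numbers, but compound 4 keeps the aromatic ring that those steps remove, so they bear on it only loosely. A small step to a higher number in this assay, near the edge of the scatter and smaller than a 4.3-fold higher number from compound 1 to compound 3 (0.63 log units; beyond the scatter), is therefore expected. The expected change is a 2.0-fold higher number from compound 1 to compound 4 (0.30 log units; within the scatter). Compound 4 is estimated at 20000 nM. The expected range for compound 4 runs from 7000 nM to 60000 nM.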

Compound 4, half-maximal cytotoxic concentration: 23000 nM
Compound 4: the middle estimate sits 1.2-fold (0.06 log units) below what was measured, and the stated range covers the measured number.
By their numbers in this assay, from the lowest: compound 1; then compounds 4 and 3 (each within the scatter of the next). At a limit, above all of these: compound 2.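

With the aromatic ring kept and only the group on it exchanged, ethoxycarbonyl in place of iodo gives in this assay a 2.3-fold higher number from compound 1 to compound 4 (0.36 log units; beyond the scatter) in a step that is modest in size. The earlier steps shown here removed the whole 4-iodophenyl, so they could not show that this single position, para to a large group, moves the number beyond the scatter on its own. Nothing given here accounts for the size or direction of this step.

As far as these compounds go, whether the higher number follows the loss of iodo or the arrival of ethoxycarbonyl stays open, with only one replacement at this position on show. How an amine, a carboxylic acid or a longer ester chain in place of iodo would read in this assay is also unknown.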